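Swapping the aryl group on the nitrogen of the shared core

A few compounds are considered here, and "the series" means these few. Any claim that something is new, unique, unknown or untested is made for them only; others in the source may bear on it.

In a functional assay on PC-9 cells (Homo sapiens) for inhibition, read by MTT assay, with a stated time of 48 h, tested at 10 uM (a lower number here means less inhibition, a higher number more inhibition at the concentration tested (going by the name of the read-out)), the three measured compounds gave the following:

compound 1 `COc1cc(NC(=O)Nc2cc(Nc3ccc(OC)c(I)c3)ncn2)cc(OC)c1`: 47.1%
compound 2 `COc1cc(NC(=O)Nc2cc(Nc3ccc(Br)cc3OC)ncn2)cc(OC)c1`: 83%
compound 3 `COc1cc(NC(=O)Nc2cc(Nc3cc(F)ccc3OC)ncn2)cc(OC)c1`: 59.5%

Compound 3 stands second of the three; compound 1 lies below it and compound 2 above it, both beyond the scatter.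

Compound 4 `COc1cc(NC(=O)Nc2cc(Nc3ccc(C)c(C)c3)ncn2)cc(OC)c1` has not been measured yet. The change from compound 3 to compound 4 is 3,4-dimethylphenyl in place of 5-fluoro-2-methoxyphenyl on a nitrogen on an aromatic ring.

Among the compounds with values here, no measured step makes exactly this swap; the measured steps exchange halogen-and-methoxy substituted phenyl groups among themselves. They show that changing the aryl group on this nitrogen can move the read-out by a modest to a large amount: a number 12.4 percentage points higher from compound 1 to compound 3 (beyond the scatter), a number 23.5 percentage points lower from compound 2 to compound 3 (beyond the scatter) and a number 35.9 percentage points higher from compound 1 to compound 2 (beyond the scatter). The direction for a phenyl bearing two methyl groups and no methoxy cannot be read from these steps.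

For compound 4 a step of about a number 4.5 percentage points lower from compound 3 to compound 4 (within the scatter) in this assay is therefore expected, with a wide range. The estimate for compound 4 is 55%, between 30% and 80%.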

Compound 4, a percentage reported as inhibition, at one concentration (the size of the read-out at that concentration, not a potency): 66%
Estimate against measurement, compound 4: 11 percentage points below, within the range that was stated.
By their numbers in this assay, from the lowest: compound 1; then compounds 3 and 4 (each within the scatter of the next); then compound 2.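

In this assay, 3,4-dimethylphenyl carries neither a methoxy group nor a halogen, unlike the three aryl groups before it, yet it does not separate from 5-fluoro-2-methoxyphenyl (a number 6.5 percentage points higher from compound 3 to compound 4 (within the scatter)), so a read-out of this size at this position needs neither of those groups. The position still tells the other aryl groups apart, with clear gaps on both sides (a number 17 percentage points lower from compound 2 to compound 4 (beyond the scatter); a number 18.9 percentage points higher from compound 1 to compound 4 (beyond the scatter)), so compound 4 sits with compound 3 in the middle of the set. No measurement shown here accounts for these differences.

Open, on these data alone, is whether an aryl group bearing an amine or a carboxylic acid would keep this level of inhibition. Also open, as far as these compounds go, is whether 4-methylphenyl, with a single methyl group, would read like 3,4-dimethylphenyl.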